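Aryl swap on the piperazine nitrogen and predicted A3 inhibition

A few compounds are considered here, and "the series" means these few. Any claim that something is new, unique, unknown or untested is made for them only; others in the source may bear on it.

Measured compounds:
compound 1, `Nc1scc(CN2CCN(c3cccc(F)c3F)CC2)c1C(=O)c1ccc(Cl)cc1`, 0%
compound 2, `Nc1scc(CN2CCN(c3cc(F)ccc3F)CC2)c1C(=O)c1ccc(Cl)cc1`, 2%

In an assay on CHO cells for displacement of a labelled ligand from adenosine receptor A3 (Homo sapiens), read by scintillation counting, with a stated time of 120 min, tested at 10 uM (a lower number here means less inhibition, a higher number more inhibition at the concentration tested (going by the name of the read-out)), compound 2 gives 2%, the higher of the two numbers shown, while compound 1 gives 0%; the step of a number 2 percentage points higher from compound 1 to compound 2 (within the scatter) lies within the scatter, so the two compounds cannot be told apart on this read-out.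

Compound 3, `Nc1scc(CN2CCN(c3cccc(Cl)c3)CC2)c1C(=O)c1ccc(Cl)cc1`, has not yet been measured. It differs from compound 2 only at the aryl group on the ring nitrogen: 3-chlorophenyl in place of 2,5-difluorophenyl on an amine nitrogen in a ring.

For the measured compounds named here, only one measured step touches the same position, the step from compound 1 to compound 2, and it exchanged one difluorophenyl pattern for another without moving the number beyond the scatter. Going by the values given here, no measured pair shows a chlorophenyl at this position, so the effect of the present change is unknown. Given that both measured compounds sit at the bottom of the scale in this assay, compound 3 is expected to stay there as well, with a step of a number 1 percentage points higher from compound 2 to compound 3 (within the scatter) that is not beyond the scatter. The estimate for compound 3 in this assay is 3%, with a range from -8% to 16%.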

Compound 3, a percentage reported as inhibition, at one concentration (the size of the read-out at that concentration, not a potency): 1%
Compound 3: the middle estimate sits 2 percentage points above what was measured, within the range that was stated.
By their numbers in this assay, from the lowest: compounds 1, 3 and 2 (each within the scatter of the next).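

In this assay, a single chlorine at 3-chlorophenyl on an amine nitrogen in a ring, in place of two fluorines, gives a number 1 percentage points lower from compound 2 to compound 3 (within the scatter) and, against the other difluorophenyl pattern, a number 1 percentage points higher from compound 1 to compound 3 (within the scatter). The position has therefore now carried a chlorophenyl as well as two difluorophenyl patterns, and neither the kind of halogen nor the number of halogens among these three compounds separates them on this read-out: compound 1, compound 2 and compound 3 cannot be told apart. Nothing measured here offers an explanation for this flat result.

Because all three compounds are halogen-bearing phenyl groups that read at the bottom of the scale at the single concentration tested, the compounds shown leave open whether any other group on this ring nitrogen, such as a methoxyphenyl, a pyridine ring or a benzyl group, would move the number at all. They also leave open whether a change elsewhere on the shared core, such as replacing the 4-chlorobenzoyl part with a simple amide or a carboxylic acid, would do so.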